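The source may report more compounds than this note shows. Statements on the series, on what has been measured and on what is new or still open speak of the compounds shown alone.

Of the compounds shown here, three have been measured in a functional assay on MCF7 cells (Homo sapiens) for antiproliferative activity, read by fluorescence, with a stated time of 3 days; on this read-out higher numbers stand for weaker inhibition and lower numbers for stronger inhibition. Compound 1 `CCCCCSc1nc(OC(=O)c2cc3ccccc3o2)c2cn[nH]c2n1` gives 18900 nM. Compound 2 `Clc1ccccc1Nc1nc(SCCc2ccccc2)nc2[nH]ncc12` gives 19200 nM. Compound 3 `CCCCCSc1nc(Nc2ccccc2Cl)c2cn[nH]c2n1` gives 19200 nM. All three numbers sit within the scatter of one another, so none of them can be called stronger or weaker than the others.

Compounds 3 and 2 share a core and differ in one place (phenyl in place of propyl on a saturated chain carbon, two bonds along the chain from a sulfur). That change produced no change at the digits printed from compound 3 to compound 2 (within the scatter). The core of compound 1 and the core of compound 3 also differ, but that difference between the two cores is not broken down here.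

Compound 4 `O=C(Oc1nc(SCCc2ccccc2)nc2[nH]ncc12)c1cc2ccccc2o1` has not yet been measured. It stands to compound 1 as compound 2 stands to compound 3: the difference is phenyl in place of propyl on a saturated chain carbon, two bonds along the chain from a sulfur, with the same description of its place, so this is the same change seen once before.

Because the earlier step was no change at the digits printed from compound 3 to compound 2 (within the scatter), a step of about a 1.0-fold higher number from compound 1 to compound 4 (0.00 log units; within the scatter) is expected here too, which means the number for compound 4 is expected near that of compound 1. The estimate for compound 4 in this assay is 19000 nM, with a likely range from 9000 nM to 40000 nM.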

Compound 4, half-maximal inhibitory concentration: 18900 nM
For compound 4 the middle estimate is 1.0-fold (0.00 log units) above the measured one; the range from low to high includes it.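

In this assay, replacing propyl with phenyl at the end of the sulfur-linked chain gave no change at the digits printed from compound 1 to compound 4 (within the scatter), and the two cores can be set side by side: the same change on two cores in this assay, no change at the digits printed (within the scatter) from compound 3 to compound 2 and no change at the digits printed (within the scatter) from compound 1 to compound 4, 1.0-fold (0.00 log units) apart, within the scatter of two such steps In this series, then, the change carried from one core to the other, and on both it left the number where it was. This does not show that the same would hold on a third core or in a different assay, and two pairs that both show no change cannot explain why the chain end makes no visible difference here.

All four compounds sit within the scatter of one another, so the compounds shown leave open whether any change to this chain can move the number at all. How a chain ending in an amine or a carboxylic acid, or a much longer chain, would read on either core remains an open question.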